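The source may report more compounds than this note shows. Statements on the series, on what has been measured and on what is new or still open speak of the compounds shown alone.

Working notes on the sulfonyl series built on the shared core of compound 1 `COc1ccc(-c2c(Br)c(=O)c3c(OC)cc(OC)cc3n2S(=O)(=O)c2ccc(OC)cc2)cc1`. Compound 2 `COc1ccc(-c2cc(=O)c3c(OC)cc(OC)cc3n2S(=O)(=O)c2ccc(C#N)cc2)cc1` carries 4-cyanophenyl on the sulfonyl sulfur, compound 3 `COc1ccc(-c2cc(=O)c3c(OC)cc(OC)cc3n2S(=O)(=O)c2cc(F)c(F)c(F)c2)cc1` carries 3,4,5-trifluorophenyl there. In a functional assay on HepG2 cells (Homo sapiens) for antiproliferative activity, with a stated time of 72 h (a lower number here means that less compound is needed, a higher number that more compound is needed for the effect), compound 1 returns no number, only the limit > 20000 nM. Compound 2 likewise returns only a limit, > 17200 nM. Compound 3 too stops at a limit, > 65500 nM. Among the measured compounds shown here, compound 3 thus stands at a limit, and the two further values shown are limits as well, so no compound in the set has a measured number. The step that the two limits leave unreadable from compound 2 to compound 3 cannot be sized because both of its ends are limits the limit of > 17200 nM in this assay, at which 1 of the 3 values shown sits (the limit of > 65500 nM in this assay, at which 1 of the 3 values shown sits). Compound 1 sits at the limit of > 20000 nM in this assay, at which 1 of the 3 values shown sits.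

Compound 4 `COc1ccc(-c2cc(=O)c3c(OC)cc(OC)cc3n2S(=O)(=O)c2ccc(OC)cc2)cc1` differs from compound 3 by 4-methoxyphenyl in place of 3,4,5-trifluorophenyl on a sulfonyl sulfur. For the measured compounds named here, no measured step bears readably on this change; the single step from compound 2 to compound 3 is unreadable, and every value so far is a limit. The expectation for compound 4 is therefore that it also remains at or near a limit, with no readable step, and the step of an at least 2.1-fold lower number from compound 3 to compound 4 (0.33 log units; beyond the scatter) is expected to be within scatter. Compound 4 is estimated at 30000 nM, with a range from 8000 nM to 120000 nM.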

Compound 4, half-maximal effective concentration: > 82700 nM
Compound 4: a limit, no number (the forecaster's own chance of this, stated with the estimate: 80%); at least 2.7-fold (0.44 log units) between middle value and limit.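

Compound 4 also stops at a limit, so no step can be read between it and compound 1, compound 2 or compound 3, which stand at limits as well. The compounds shown leave open whether any group on the sulfonyl sulfur, or hydrogen in place of bromo on an aromatic carbon, changes the result in this assay.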